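Isopropyl in place of cyclopropyl on the aromatic nitrogen

The source may hold more compounds than are shown below. What is called first, only, known or untested is meant among the compounds shown, and "the series" means these compounds.

In a physicochemical assay for lipophilicity (on this read-out lower numbers stand for lower lipophilicity and higher numbers for higher lipophilicity), compound 3 `N#Cc1ccc(Oc2cc(-c3cnnc4c3ncn4C3CC3)ccc2F)nc1` gives 2.3, level with compound 2 `CCn1cnc2c(-c3ccc(F)c(Oc4ccc(C#N)cn4)c3)cnnc21` at 2.3. Together they hold the highest of the three numbers. Compound 1 `CC(=O)N1CC(Oc2cc(-c3cnnc4c3ncn4C(C)C)ccc2F)C1` stands lower at 1.6, a gap beyond the scatter.

The next structure, compound 4 `CC(C)n1cnc2c(-c3ccc(F)c(Oc4ccc(C#N)cn4)c3)cnnc21`, has isopropyl in place of cyclopropyl on an aromatic nitrogen. Going by the values given here, no measured step joins these two groups directly. Compound 1 also carries isopropyl on an aromatic nitrogen, but it differs from compound 4 elsewhere, so its value offers no direct guide.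

The closest evidence is a single step with cyclopropyl in place of ethyl on an aromatic nitrogen: no change at the digits printed from compound 2 to compound 3 (within the scatter). Among the compounds with values here, with that step as the only guide, no change beyond the scatter is expected in this assay. The expected step is a number 0.20 log units higher from compound 3 to compound 4 (within the scatter), a slight rise that stays within the scatter. Compound 4 is estimated at 2.5, with an expected range of 2.2 to 2.8.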

Compound 4, distribution coefficient: 2.7
Estimate against measurement, compound 4: 0.20 log units below; measured number inside the range.
By their numbers in this assay, from the lowest: compound 1; then compounds 2 and 3 (each within the scatter of the next); then compound 4.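

In this assay the group on the aromatic nitrogen now makes a difference: isopropyl in place of cyclopropyl gives a number 0.40 log units higher from compound 3 to compound 4 (beyond the scatter), and methyl in place of hydrogen on the saturated chain carbon gives a number 0.40 log units higher from compound 2 to compound 4 (beyond the scatter), although ethyl and cyclopropyl had shown no change at the digits printed from compound 2 to compound 3 (within the scatter). With isopropyl common to both compounds, 5-cyanopyridin-2-yl in place of 1-acetylazetidin-3-yl on an oxygen on an aromatic ring gives a number 1.10 log units higher from compound 1 to compound 4 (beyond the scatter), so this second place also has a step of its own, one beyond the scatter. Nothing measured here accounts for these steps.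

Still open, from the compounds shown here alone, is how a tert-butyl group or a longer chain such as n-butyl would read at the aromatic nitrogen. Also open, going by these compounds, is whether the isopropyl and cyclopropyl step would hold with 1-acetylazetidin-3-yl on the oxygen.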